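The compounds below may be only part of what the source reports. "The series", "measured", "known", "first", "only" and "open" are said of these compounds alone.

Compound 1, with the structure `CN1CCC[C@@H]1Cn1nc(Cc2ccc(F)cc2)c2ccccc2c1=O`, is the starting point. In an assay for binding affinity to Alpha-1A adrenergic receptor (Homo sapiens) (a lower number here means a stronger inhibitor, a higher number a weaker inhibitor), compound 1 gives 63.1 nM, which places it second highest of the three numbers at hand. Compound 3, with the structure `O=c1c2ccccc2c(Cc2ccc(Cl)cc2)nn1C[C@H]1CCCN1CCCCCc1ccc(OCCCN2CCCCCC2)cc1`, gives 25.1 nM in this assay, a lower number than compound 1. Compound 2, with the structure `COc1cccc(Cc2nn(C[C@H]3CCCN3C)c(=O)c3ccccc23)c1`, gives 1580 nM, and the change a 25-fold higher number from compound 1 to compound 2 (1.40 log units; beyond the scatter), brought about by a 3-methoxyphenyl in place of a 4-fluorophenyl on a saturated chain carbon bound to an aromatic carbon, is a large one.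

Compound 4, with the structure `CN1CCC[C@@H]1Cn1nc(Cc2ccc(F)c(F)c2)c2ccccc2c1=O`, differs from compound 1 by fluoro in place of hydrogen on an aromatic carbon, which read one bond further out is 4-fluorobenzyl to 3,4-difluorobenzyl. Among the compounds with values here, no measured step shows a fluoro entering this ring; the only step available swaps the whole aryl group. For compound 4 in this assay a step of a 1.0-fold lower number from compound 1 to compound 4 (0.00 log units; within the scatter) is therefore expected, within the scatter, and the number for compound 4 is estimated at 63 nM, between 25 nM and 160 nM.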

Compound 4, inhibition constant: 200 nM
Beside the measured number, compound 4's estimate is 3.2-fold (0.50 log units) below it, and the stated range ends below it.
By their numbers in this assay, from the lowest: compound 3; then compound 1; then compound 4; then compound 2.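

In this assay the step of a 3.2-fold higher number from compound 1 to compound 4 (0.50 log units; beyond the scatter) shows that this aromatic carbon, ortho to a fluoro group, is sensitive to a single added fluoro, whereas the earlier step replaced the whole aryl group. The step of a 7.9-fold lower number from compound 2 to compound 4 (0.90 log units; beyond the scatter) adds that the two replacements of 4-fluorophenyl, 3,4-difluorophenyl and 3-methoxyphenyl, both raise the number but do so to different extents. No measurement presented here accounts for either step.

The compounds shown leave open whether the rise is specific to fluoro or would also follow a methyl or a nitrile on this same carbon. They also leave open how a methoxy on this carbon would behave with the 4-fluoro group kept in place.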